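Halogen swap on the acetyl-bearing core, cytotoxicity series

The source may report more compounds than this note shows. Statements on the series, on what has been measured and on what is new or still open speak of the compounds shown alone.

Three members of the series have been run in a functional assay on KB cells (Homo sapiens) for cytotoxicity, read by spectrophotometry and crystal violet staining; a higher number here means a weaker inhibitor, a lower number a stronger inhibitor. Compound 1 `N#Cc1c(Cl)n(C2O[C@H](CN=[N+]=[N-])[C@@H](O)[C@H]2O)c2cc(Cl)c(Cl)cc12` gives 60000 nM. Compound 2 `O=Cc1c(Cl)n(C2O[C@H](CF)[C@@H](O)[C@H]2O)c2cc(Cl)c(Cl)cc12` gives 20000 nM. Compound 3 `CC(=O)c1c(Br)n([C@H]2C[C@H](O)[C@@H](CO)O2)c2cc(Cl)c(Cl)cc12` differs from both in the sugar part and in the acetyl group, and for compound 3 this assay returned only a limit, > 100000 nM, not a number; so compound 3 stands at the limit of > 100000 nM in this assay, at which 1 of the 3 values shown sits, and its place relative to compound 1 and compound 2 can only be said to be at or beyond the weaker end of the numbers seen.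

The next compound, compound 4 `CC(=O)c1c(Cl)n([C@H]2C[C@H](O)[C@@H](CO)O2)c2cc(Cl)c(Cl)cc12`, is compound 3 with a single change: chloro in place of bromo on an aromatic carbon. For the measured compounds named here, no measured pair in the set differs in exactly this way, so no measured step can be borrowed for it. A halogen-for-halogen exchange of this kind, without change in ring count, donors, acceptors or charge, is expected to move this assay by no more than the usual scatter, in no particular direction.

Compound 4 is therefore estimated at 100000 nM, with a range from 30000 nM to 300000 nM. The step this implies, a number no higher from compound 3 to compound 4 (the limit leaves the size open), is expected to lie within the scatter, and a second limit rather than a number is expected to be the likelier outcome.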

Compound 4, half-maximal inhibitory concentration: 400000 nM
For compound 4 the middle estimate is 4.0-fold (0.60 log units) below the measured one; the whole stated range lies below it.
By their numbers in this assay, from the lowest: compound 2; then compound 1; then compound 4.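

For the compounds shown here, no step from compound 3 to compound 4 can be read, because compound 3 has only a limit in this assay, not a number: the limit of > 100000 nM in this assay, at which 1 of the 4 values shown sits.

The compounds shown leave open whether chloro in place of bromo on an aromatic carbon changes this assay at all, and in which direction, since no other pair here differs in that way.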